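Fluoro for Nitro on a Weakly Antiproliferative Urea

This account rests on a few compounds, and the source may have more. Where it says the series, first, only, none or still open, it means among the compounds named here.

Compound 1 `O=C(Nc1ccccc1)Nc1ccc(OC(=O)c2ccccc2)cc1` and compound 2 `O=C(Nc1ccccc1)Nc1ccc(OC(=O)c2ccc([N+](=O)[O-])cc2)cc1` share one core. In a functional assay on HT-29 cells (Homo sapiens) for antiproliferative activity, read by MTT assay, with a stated time of 48 h (on this read-out higher numbers stand for weaker inhibition and lower numbers for stronger inhibition), compound 1 gives 123000 nM and compound 2 gives 185000 nM. Of these two numbers, that of compound 2 is the higher, but the step from one to the other, a 1.5-fold higher number from compound 1 to compound 2 (0.18 log units; within the scatter), lies within the scatter, so the two compounds cannot really be told apart. Compound 3 `O=C(Nc1ccccc1)Nc1ccc(OC(=O)c2ccc(F)cc2)cc1` differs from compound 2 by fluoro in place of nitro on an aromatic carbon. For the measured compounds named here, no measured step exchanges these two groups directly; the only step at hand, hydrogen to nitro at the same spot, produced nothing beyond noise, which suggests that what sits at this position has had little effect so far. A flat outcome is therefore expected for compound 3 as well, a step of a 1.2-fold lower number from compound 2 to compound 3 (0.09 log units; within the scatter). In this assay compound 3 is estimated at 150000 nM, between 60000 nM and 350000 nM.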

Compound 3, half-maximal inhibitory concentration: 128000 nM
Compound 3: the middle estimate sits 1.2-fold (0.07 log units) above what was measured; low and high end bracket the measured number.
By their numbers in this assay, from the lowest: compounds 1, 3 and 2 (each within the scatter of the next).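

In this assay, putting fluoro in place of nitro gives a 1.4-fold lower number from compound 2 to compound 3 (0.16 log units; within the scatter), and putting fluoro in place of hydrogen gives a 1.0-fold higher number from compound 1 to compound 3 (0.02 log units; within the scatter). For the compounds shown here, the earlier compounds offered only one exchange at this position, on an aromatic carbon para to a large group; now hydrogen, nitro and fluoro can all be compared there, and no pair among compound 1, compound 2 and compound 3 can be told apart. No supporting measurement is available to explain why these three compounds stay so close.

Still open, going by these compounds, is whether any group at this position can shift the number beyond the scatter, for example an amine, a carboxylic acid or a longer chain. Equally open, on these data alone, is whether changes elsewhere on the shared core would matter more than this one.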